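Compound 3 to compound 4: replacing 1H-pyrrol-1-yl

The compounds below may be only part of what the source reports. "The series", "measured", "known", "first", "only" and "open" are said of these compounds alone.

Of the compounds shown here, three on the shared core have been tested in an ADME assay on HeLa cells (Homo sapiens) for cytotoxicity, read by crystal violet staining, with a stated time of 72 h; a lower number here means that less compound is tolerated, a higher number that more compound is tolerated. Compound 1 (`CCOC(=O)c1cc(CCCOc2ccc(-c3noc(C(F)(F)F)n3)cc2[N+](=O)[O-])on1`) gives > 100000 nM, which is a limit of the assay. Compound 2 (`CCOC(=O)c1cc(CCCOc2ccc(-c3noc(C(F)(F)F)n3)cc2N)on1`) gives > 100000 nM, again a limit. Going by the values given here, compound 3 (`CCOC(=O)c1cc(CCCOc2ccc(-c3noc(C(F)(F)F)n3)cc2-n2cccc2)on1`) gives 57300 nM, the only actual number so far.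

Compound 4 (`CCOC(=O)c1cc(CCCOc2ccc(-c3noc(C(F)(F)F)n3)cc2/N=C/N(C)C)on1`) changes the same aromatic carbon, which is ortho to a large group: a group of 5 heavy atoms (3 carbon, 2 nitrogen; no ring) in place of a group of 5 heavy atoms (4 carbon, 1 nitrogen; one five-membered aromatic ring with 1 hetero atom), on an aromatic carbon. The entering group has no ring, whereas 1H-pyrrol-1-yl is a five-membered aromatic ring.

Three measured steps change the group at this carbon. Two give only floors, an at least 1.7-fold lower number from compound 1 to compound 3 (0.24 log units; that floor lies within the scatter) and an at least 1.7-fold lower number from compound 2 to compound 3 (0.24 log units; that floor lies within the scatter), and neither shows a change beyond the scatter. The third, a step that the two limits leave unreadable from compound 1 to compound 2, has no readable size. Also relevant is the limit of > 100000 nM in this assay, at which 2 of the 3 values shown sit, so a limit rather than a number is a real possibility for compound 4.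

With no measured step beyond the scatter at this carbon, no shift in either direction can be supported. The expected result is a 1.0-fold higher number from compound 3 to compound 4 (0.02 log units; within the scatter), a change not expected to exceed the scatter. For compound 4 the estimated value is 60000 nM, with an expected range of 25000 nM to 100000 nM.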

Compound 4, half-maximal cytotoxic concentration: > 100000 nM
Compound 4 was reported as a limit (the forecaster's own chance of this, stated with the estimate: 35%); middle value at least 1.6-fold (0.22 log units) away from the limit.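

In this assay, the group with no ring in place of 1H-pyrrol-1-yl gives an at least 1.7-fold higher number from compound 3 to compound 4 (0.24 log units; that floor lies within the scatter), so this change, like the earlier ones at this aromatic carbon, shows no step beyond the scatter. The two groups have the same counts of heavy atoms, hydrogen-bond donors and hydrogen-bond acceptors, and this pair adds a ring-for-no-ring comparison, but only as a floor; the steps to compound 4 from compound 1 and compound 2 cannot be read, as both ends of each are limits. Compound 3 remains the only compound with an actual number, and the limit now covers most of the series: the limit of > 100000 nM in this assay, at which 3 of the 4 values shown sit.

Going by these compounds, whether the true values of compound 1, compound 2 and compound 4 differ from one another, or from compound 3 by more than the scatter, stays open. On these data alone, it is also open whether another group at this carbon, such as an acetamide, a dimethylamino group or a phenyl ring, would give a number in this assay and a step that can be read beyond the scatter.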